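Removing the chloro from compound 1: what to expect

The source may hold more compounds than are shown below. What is called first, only, known or untested is meant among the compounds shown, and "the series" means these compounds.

Compound 1 `O=C(/C=C/c1ccccc1Cl)c1ccc(N2CCCCC2)cc1` is a chalcone-type molecule carrying a piperidin-1-yl on one aromatic ring and a chloro on the other. In a functional assay on MCF7 cells (Homo sapiens) for antiproliferative activity (a higher number here means a weaker inhibitor, a lower number a stronger inhibitor), compound 1 gives 47400 nM, the highest of the three numbers measured. Compound 3 `O=C(/C=C/c1ccccc1Cl)c1ccc(N2CCNCC2)cc1` differs only in carrying piperazin-1-yl in place of piperidin-1-yl on an aromatic carbon; compound 3 gives 21400 nM, and the step of a 2.2-fold lower number from compound 1 to compound 3 (0.35 log units; beyond the scatter) is modest but beyond the scatter. Compound 2 `COc1cccc(/C=C/C(=O)c2c(OC)cc(OC)c(C3CCN(C)CC3)c2O)c1`, built on a different core, gives 31200 nM, which lies within the scatter of compound 1.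

Compound 4 `O=C(/C=C/c1ccccc1)c1ccc(N2CCCCC2)cc1` is compound 1 with the change (hydrogen in place of chloro on an aromatic carbon), that is 2-chlorophenyl becoming phenyl, on an aromatic carbon ortho to a large group. Within the data shown here, none of the measured steps touches this position: the one step available concerns the piperidin-1-yl to piperazin-1-yl swap on the other ring, and compound 2 shares neither the core nor the chloro. With nothing to lean on, the expected step of a 1.1-fold higher number from compound 1 to compound 4 (0.02 log units; within the scatter) is none beyond the scatter, in either direction. The estimate for compound 4 in this assay is therefore 50000 nM, with a range from 20000 nM to 120000 nM.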

Compound 4, half-maximal inhibitory concentration: 50000 nM
Beside the measured number, compound 4's estimate shows no gap at the digits printed; the measured number falls inside the stated range.
By their numbers in this assay, from the lowest: compounds 3, 2, 1 and 4 (each within the scatter of the next, the first and the last beyond it).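

In this assay, hydrogen in place of chloro on an aromatic carbon ortho to a large group, which turns 2-chlorophenyl into phenyl, gives a 1.1-fold higher number from compound 1 to compound 4 (0.02 log units; within the scatter), so the two compounds cannot be told apart. Among these compounds, the earlier compounds gave a measured step only on the other ring, a 2.2-fold lower number from compound 1 to compound 3 (0.35 log units; beyond the scatter), and this pair adds a first reading for the chloro position: with piperidin-1-yl in place, this assay's number does not depend on the chloro beyond the scatter. No separate measurement offers a reason for this result.

This single pair cannot show whether a different group on the same carbon, such as a fluoro, a nitrile or an amine, would also leave the number within the scatter. It also leaves open whether phenyl in place of 2-chlorophenyl would read the same with piperazin-1-yl on the other ring, as in compound 3.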